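The source may report more compounds than this note shows. Statements on the series, on what has been measured and on what is new or still open speak of the compounds shown alone.

Two compounds share one core. Compound 1 `CCCCNc1nc(N)nnc1OCc1ccccc1F` and compound 2 `CCCCNc1nc(N)nnc1OCc1ccccc1` differ only in that hydrogen replaces fluoro on an aromatic carbon. In an assay on isolated protein for agonist activity at Toll-like receptor 8 (Homo sapiens) (a lower number here means that less compound is needed, a higher number that more compound is needed for the effect), compound 1 gives 560 nM; in this assay compound 2 gives 1930 nM, and the step is a 3.4-fold higher number from compound 1 to compound 2 (0.54 log units; beyond the scatter). Compound 2 thus stands as the higher of the two numbers. Compound 3 `CCCCNc1nc(N)nnc1OCc1cccnc1` takes another route: pyridin-3-yl in place of phenyl on a saturated chain carbon bound to an oxygen on an aromatic ring. Going by the values given here, no measured step covers this kind of exchange; the fluoro-to-hydrogen step concerns a different part of the molecule. The expectation therefore rests on compound 2 alone, with no step beyond the scatter assumed. Compound 3 is expected to give 2000 nM, with a range from 700 nM to 6000 nM. That estimate means a step of a 1.0-fold higher number from compound 2 to compound 3 (0.02 log units; within the scatter).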

Compound 3, half-maximal effective concentration: 590 nM
Compound 3: middle estimate off by 3.4-fold (0.53 log units), on the high side, and the stated range ends above it.
By their numbers in this assay, from the lowest: compounds 1 and 3 (each within the scatter of the next); then compound 2.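

The ring on the saturated chain carbon bound to an oxygen on an aromatic ring is a place where the ring itself matters: pyridin-3-yl in place of phenyl gives a 3.3-fold lower number from compound 2 to compound 3 (0.51 log units; beyond the scatter) and so joins the fluoro as a second change that counts here. Set against 2-fluorophenyl, pyridin-3-yl gives a 1.1-fold higher number from compound 1 to compound 3 (0.02 log units; within the scatter) and so leaves the two changes level. Nothing measured here explains either step.

Still open, going by these compounds, is whether a fluoro on the pyridin-3-yl would change the number further. A chloro or methoxy group on the phenyl might also match the fluoro of compound 1.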